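The source may report more compounds than this note shows. Statements on the series, on what has been measured and on what is new or still open speak of the compounds shown alone.

Working notes on the series.

Of the compounds shown here, two carry numbers so far. Compound 1 `COc1cncc(C2=CC3CC(C2)CN(C)C3)c1` gives 596 nM in an in vitro assay on SH-SY5Y cells for displacement of a labelled ligand from Neuronal acetylcholine receptor; alpha3/beta4 (Homo sapiens); a higher number here means a weaker inhibitor, a lower number a stronger inhibitor. Compound 2 `CN1CC2C=C(c3cncc(Cl)c3)CC(C2)C1` gives 1830 nM in this assay. Of the two numbers shown, compound 2 stands highest, its nearest neighbour being compound 1; the one step between them, chloro in place of methoxy on an aromatic carbon, reads a 3.1-fold higher number from compound 1 to compound 2 (0.49 log units; beyond the scatter).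

The next compound, compound 3 `CC(C)Oc1cncc(C2=CC3CC(C2)CN(C)C3)c1`, has not been measured in this assay. Against compound 2 the change is isopropoxy in place of chloro on an aromatic carbon, two atoms from the ring nitrogen and meta to a large group.

For the measured compounds named here, only the step from compound 1 to compound 2 bears on this change, and it ran in the other direction: removing an alkoxy group for chloro gave a 3.1-fold higher number from compound 1 to compound 2 (0.49 log units; beyond the scatter). Going by the values given here, no measured pair compares isopropoxy with methoxy, so the size of that alkoxy is an open point. Putting an alkoxy back is therefore expected to lower the number again, with the step from compound 2 to compound 3 estimated as a 2.4-fold lower number from compound 2 to compound 3 (0.39 log units; beyond the scatter). For compound 3 the estimate in this assay is 750 nM, with a range from 250 nM to 2500 nM.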

Compound 3, inhibition constant: 1730 nM
Estimate against measurement, compound 3: 2.3-fold (0.36 log units) below; the measured number falls inside the stated range.
By their numbers in this assay, from the lowest: compound 1; then compounds 3 and 2 (each within the scatter of the next).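

At this position an alkoxy group alone does not separate a compound from the chloro compound: in this assay, isopropoxy in place of chloro reads a 1.1-fold lower number from compound 2 to compound 3 (0.02 log units; within the scatter), so compound 2 and compound 3 cannot be ordered on these numbers. The alkyl group on the oxygen matters instead, since isopropyl in place of methyl reads a 2.9-fold higher number from compound 1 to compound 3 (0.46 log units; beyond the scatter), a step of about the same size as the one from methoxy to chloro, a 3.1-fold higher number from compound 1 to compound 2 (0.49 log units; beyond the scatter). Among these three compounds the lower number therefore belongs to the methoxy compound alone, and compound 3 goes against any reading that credits alkoxy groups in general; no measurement at hand gives a reason for this.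

From the compounds shown here alone, whether the number climbs gradually with the group on the oxygen or already reaches its upper level with the next alkyl group stays open, and ethoxy would sit directly on that question. Equally open, going by these compounds, is how a hydroxyl or an amino group at this position would compare with methoxy in this assay, and whether a longer alkoxy chain would stay level with compound 3.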